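Swapping a biaryl for a diaryl ether: solubility expectation

This account rests on a few compounds, and the source may have more. Where it says the series, first, only, none or still open, it means among the compounds named here.

Compound 3 `COc1ccc(-c2ccc3c(NCCCNCc4ccco4)ccnc3c2)cc1`: 32000 nM
Compound 2 `c1ccc(Oc2ccc3c(NCCCNCc4ccco4)ccnc3c2)cc1`: 14500 nM
Compound 1 `Cc1cc(C)cc(Cc2ccc3c(NCCCNCc4ccco4)ccnc3c2)c1`: 4200 nM

In a physicochemical assay for solubility, with a stated time of 18 h, at pH 7.4 (a higher number here means a more soluble compound, a lower number a less soluble compound), compound 3 gives the highest of the three numbers, standing a 2.2-fold higher number from compound 2 to compound 3 (0.34 log units; beyond the scatter) and a 7.6-fold higher number from compound 1 to compound 3 (0.88 log units; beyond the scatter). Compound 4 `COc1ccc(Oc2ccc3c(NCCCNCc4ccco4)ccnc3c2)cc1` differs from compound 3 by one change: 4-methoxyphenoxy in place of 4-methoxyphenyl on an aromatic carbon. The step that bears most on this is the one between phenoxy and 4-methoxyphenyl, where a 2.2-fold higher number from compound 2 to compound 3 (0.34 log units; beyond the scatter); run the other way, exchanging an aryl link for an aryloxy link cost a modest amount. The methoxy group itself stays in place, so that gain is not lost. Compound 4 is therefore expected to sit a little below compound 3, a step of a 1.6-fold lower number from compound 3 to compound 4 (0.20 log units; within the scatter) in this assay, near the scatter edge. The estimate for compound 4 is 20000 nM, with a range from 8000 nM to 50000 nM.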

Compound 4, solubility: 14500 nM
Compound 4: middle estimate off by 1.4-fold (0.14 log units), on the high side, and the stated range covers the measured number.
By their numbers in this assay, from the lowest: compound 1; then compounds 2 and 4 (each within the scatter of the next); then compound 3.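

In this assay, holding the methoxy in place isolates the link to the core: a 2.2-fold lower number from compound 3 to compound 4 (0.34 log units; beyond the scatter). Methoxy in place of hydrogen on the phenoxy ring gives no change at the digits printed from compound 2 to compound 4 (within the scatter), so at this position the methoxy shows no effect on the oxygen-linked group, and the earlier gap between phenoxy and 4-methoxyphenyl stays once the methoxy is matched. 4-Methoxyphenoxy in place of 3,5-dimethylbenzyl gives a 3.5-fold higher number from compound 1 to compound 4 (0.54 log units; beyond the scatter).

From the compounds shown here alone, whether an amine or a carboxylic acid on this aromatic carbon would read differently stays open. Nothing shown gives a reason for the cost of the oxygen link.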